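Swapping 4-chlorophenyl for benzyl on a shared core

A few compounds are considered here, and "the series" means these few. Any claim that something is new, unique, unknown or untested is made for them only; others in the source may bear on it.

Among the measured compounds shown here, in a toxicity assay on cells (Macrophage, Mus musculus, strain BALB/c) for cytotoxicity, read by MTT assay (a higher number here means a weaker inhibitor, a lower number a stronger inhibitor), compound 1 (`COc1cc(O)cc(O)c1C(=O)/C=C/c1ccc(Cl)cc1`) gives 19000 nM and sits level, within the usual scatter, with compound 2 (`COc1cc(O)cc(O)c1C(=O)/C=C/c1ccc(C(F)(F)F)cc1`) at 17100 nM as the only other number so far. Compound 3 (`COc1cc(O)cc(O)c1C(=O)/C=C/Cc1ccccc1`) keeps the rest of compound 1 but has benzyl in place of 4-chlorophenyl on a double-bonded chain carbon bound to a double-bonded chain carbon. For the measured compounds named here, the only measured step, a 1.1-fold lower number from compound 1 to compound 2 (0.05 log units; within the scatter) with trifluoromethyl in place of chloro on an aromatic carbon, stays within the scatter. Going by the values given here, it bears only loosely on the new change: no measured compound carries benzyl. On this single guide, no shift beyond the scatter is expected in this assay, and the estimated step is a 1.2-fold higher number from compound 1 to compound 3 (0.06 log units; within the scatter) with no firm direction. For compound 3 the expected value is 22000 nM (range 10000 nM to 50000 nM).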

Compound 3, half-maximal inhibitory concentration: 27000 nM
Compound 3: the middle estimate sits 1.2-fold (0.09 log units) below what was measured; measured number inside the range.
By their numbers in this assay, from the lowest: compounds 2, 1 and 3 (each within the scatter of the next).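

The earlier step altered only the small group on the ring, trifluoromethyl in place of chloro, whereas this one replaces the whole 4-chlorophenyl with benzyl, which has the same heavy-atom count and the same kind of ring but no chlorine. In this assay this larger swap gives a 1.4-fold higher number from compound 1 to compound 3 (0.15 log units; within the scatter) and so stays level with compound 1, which means that at this position the change from 4-chlorophenyl to benzyl does not separate the two compounds in this cell test. Nothing available explains this result.

Going by these compounds, whether an amine or a carboxylic acid in place of the ring would move the number beyond the scatter remains open. So does the effect of a longer chain carrying the phenyl ring.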